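The compounds below may be only part of what the source reports. "The series", "measured", "known", "first", "only" and "open" are said of these compounds alone.

Compound 1 `Cc1cc(Br)cc(C)c1Oc1cc(Nc2ccc(C#N)cc2)c(N)cc1N`: 38400 nM
Compound 2 `Cc1cc(C#N)cc(C)c1Oc1ccc([N+](=O)[O-])c(Nc2ccc(C#N)cc2)c1`: > 65100 nM (a limit)

For the measured compounds named here, in an ADME assay on H9 cells (Homo sapiens) for cytotoxicity, read by XTT assay, with a stated time of 6 days (on this read-out lower numbers stand for higher toxicity in this test and higher numbers for lower toxicity in this test), compound 1 gives 38400 nM, the only actual number so far. Going by the values given here, the single other reading is a limit and not a number: the limit of > 65100 nM in this assay, at which 1 of the 2 values shown sits. Compound 1 therefore has no measured neighbour against which it can be ranked.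

Next in line is compound 3 `Cc1cc(C)c(Oc2cc(Nc3ccc(C#N)cc3)c(N)cc2N)c(C)c1`, which differs from compound 1 by methyl in place of bromo on an aromatic carbon. This puts methyl in place of bromo on an aromatic carbon, turning 4-bromo-2,6-dimethylphenyl into 2,4,6-trimethylphenyl. Among the compounds with values here, no measured step covers this change, so the value of compound 1 at 38400 nM is the sole anchor. No shift beyond the usual scatter is expected in this assay, and the expected change is a 1.0-fold higher number from compound 1 to compound 3 (0.02 log units; within the scatter). For compound 3 the estimate is 40000 nM, with an expected range of 15000 nM to 90000 nM.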

Compound 3, half-maximal cytotoxic concentration: 50000 nM
Estimate against measurement, compound 3: 1.3-fold (0.10 log units) below, within the range that was stated.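

The exchange of 4-bromo-2,6-dimethylphenyl for 2,4,6-trimethylphenyl gives the series its first measured single-place step, and in this assay it reads as a 1.3-fold higher number from compound 1 to compound 3 (0.11 log units; within the scatter) with the shared core unchanged. Bromo and methyl at this position, para to a large group, are therefore not told apart by this read-out. No measured property at hand bears on this step.

Open, on these data alone, is whether a carboxylic acid or a longer chain such as propyl at this same position would move the number beyond the usual scatter in this assay. Compound 2 stands at > 65100 nM which is a limit and not a number, and it differs from compound 1 in more than one place, so it anchors no comparison.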